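Imidazolyl for Pyrazolyl on a Flat Series

The source may report more compounds than this note shows. Statements on the series, on what has been measured and on what is new or still open speak of the compounds shown alone.

Three measured compounds share a common core and an aryl-linked five-membered heterocycle. Compound 1 `CC(C)n1ncnc1-c1ccccc1NCC1=NCCN1` gives 0% in a functional assay with Alpha-1B adrenergic receptor (Homo sapiens) as the target, read by calcium flux; on this read-out higher numbers stand for larger maximal responses and lower numbers for smaller maximal responses. Compound 2 `CCn1cc(-c2ccccc2NCC2=NCCN2)cn1` gives 0% in this assay, and compound 3 `Cn1cc(-c2ccccc2NCC2=NCCN2)cn1` gives 0% in this assay. Within the data shown here, the only single-point step among them, no change at the digits printed from compound 2 to compound 3 (within the scatter), changes nothing beyond the scatter. Compound 3 therefore stands level with compound 1 and compound 2 at the digits shown.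

Compound 4 `Cn1ccnc1-c1ccccc1NCC1=NCCN1` differs from compound 3 by 1-methyl-1H-imidazol-2-yl in place of 1-methyl-1H-pyrazol-4-yl on an aromatic carbon. No measured step exchanges one five-membered heterocycle for another on that aromatic carbon, so no step bears directly on this change; the one step shown, no change at the digits printed from compound 2 to compound 3 (within the scatter), concerns hydrogen in place of methyl on a saturated chain carbon bound to an aromatic nitrogen and is flat. Compound 1 carries a different five-membered heterocycle on the same aromatic carbon and also gives 0%. On that basis compound 4 is expected to remain flat, with a step of no change at the digits printed from compound 3 to compound 4 (within the scatter) from compound 3 that stays within the scatter. The estimate for compound 4 in this assay is 0%, with a range from 0% to 10%.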

Compound 4, largest response reached (reported as maximal response), in percent of the reference or control that the assay uses: 104%
The estimate for compound 4 lay 104 percentage points below the measured number, and the stated range ends below it.
By their numbers in this assay, from the lowest: compounds 1, 2 and 3 (each within the scatter of the next); then compound 4.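

In this assay, 1-methyl-1H-imidazol-2-yl in place of 1-methyl-1H-pyrazol-4-yl gives a number 104 percentage points higher from compound 3 to compound 4 (beyond the scatter), so this aromatic carbon, which had seemed silent across the flat compounds, proves highly sensitive to the five-membered heterocycle it carries. The two groups have the same atoms, the same ring size and the same counts of donors and acceptors, so those counts do not separate them, and the large step arises between two groups that differ only in how those atoms are joined. Nothing at hand explains why this rearrangement has so large an effect on the maximal response.

Whether the high response depends on the methyl group of the imidazole remains open, since the compounds shown do not include the unsubstituted 1H-imidazol-2-yl or the longer-chain 1-ethyl-1H-imidazol-2-yl. As far as these compounds go, it is equally open whether the response is particular to the imidazole or extends to another heterocycle joined at the carbon between its two hetero atoms, such as thiazol-2-yl.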